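Triazole acetamides: chloro in place of methoxy

A few compounds are considered here, and "the series" means these few. Any claim that something is new, unique, unknown or untested is made for them only; others in the source may bear on it.

Measured so far:
compound 1, `Cc1cc(NC(=O)Cn2cc(-c3ccc([N+](=O)[O-])cc3)nn2)no1`, 1220 nM
compound 2, `COc1ccc(-c2cn(CC(=O)Nc3nc4ccccc4s3)nn2)cc1`, 1330 nM
compound 3, `COc1cccc(-c2cn(-c3ccc(C(F)(F)F)cc3)nc2C(=O)NC2CCCCC2)c1`, > 30000 nM (a limit)

In a functional assay on BMDM cells (Mus musculus, strain C57BL/6) for inhibition, with a stated time of 2 days (a lower number here means a stronger inhibitor, a higher number a weaker inhibitor), compound 1 gives 1220 nM and compound 2 gives 1330 nM; the two numbers lie within the scatter of each other, so no order between them can be read. Compound 3 returns only a limit, > 30000 nM, which is the limit of > 30000 nM in this assay, at which 1 of the 3 values shown sits. Compound 4, `O=C(Cn1cc(-c2ccc(Cl)cc2)nn1)Nc1nc2ccccc2s1`, differs from compound 2 by chloro in place of methoxy on an aromatic carbon. For the measured compounds named here, no measured pair in this set isolates that change, so the expectation rests on compound 2 alone: the step of a 1.2-fold lower number from compound 2 to compound 4 (0.08 log units; within the scatter) is expected to be small, not clearly beyond the scatter, with no direction favoured. Compound 4 is therefore estimated at 1100 nM, between 400 nM and 3500 nM.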

Compound 4, half-maximal inhibitory concentration: 130 nM
Beside the measured number, compound 4's estimate is 8.5-fold (0.93 log units) above it, outside the stated range (below it).
By their numbers in this assay, from the lowest: compound 4; then compounds 1 and 2 (each within the scatter of the next). At a limit, above all of these: compound 3.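

For the compounds shown here, the 4-methoxyphenyl to 4-chlorophenyl change gives the first single-place comparison, and in this assay it produces a 10-fold lower number from compound 2 to compound 4 (1.01 log units; beyond the scatter). The number therefore responds strongly to the group on this aromatic carbon, para to a large group, which the earlier values could not show. No measurement shown accounts for this step.

On these data alone, it remains open whether fluoro, bromo, methyl or an amine at this position would give a similar number. As far as these compounds go, it is also open whether chloro would produce a similar step on the core of compound 1.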